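One amide group swapped in a level series

The compounds below may be only part of what the source reports. "The series", "measured", "known", "first", "only" and "open" are said of these compounds alone.

Compound 1 (`Cc1ccc(-c2cc(C(=O)Nc3ccncc3)nn2-c2ccc3ccccc3n2)cc1`), compound 2 (`COc1ncccc1NC(=O)c1cc(-c2ccc(C)cc2)n(-c2ccc3ccccc3n2)n1`) and compound 3 (`Cc1ccc(-c2cc(C(=O)Nc3ncc(Br)cc3Br)nn2-c2ccc3ccccc3n2)cc1`) share one core and differ only in the group on an amide-type nitrogen. In a functional assay on Huh-7 cells (Homo sapiens) for cytotoxicity, read by sulforhodamine B assay, with a stated time of 72 h (on this read-out lower numbers stand for stronger inhibition and higher numbers for weaker inhibition), compound 1 gives 8000 nM, compound 2 gives 7900 nM and compound 3 gives 11500 nM. Compound 3 therefore cannot be told apart from the other two on these numbers.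

The next structure, compound 4 (`Cc1ccc(-c2cc(C(=O)Nc3ccncc3Br)nn2-c2ccc3ccccc3n2)cc1`), carries 3-bromopyridin-4-yl in place of 3,5-dibromopyridin-2-yl on an amide-type nitrogen. The core stays untouched, so the measured steps at this same place are the ones that bear on the change. They are a 1.4-fold higher number from compound 1 to compound 3 (0.16 log units; within the scatter), a 1.5-fold higher number from compound 2 to compound 3 (0.16 log units; within the scatter) and a 1.0-fold lower number from compound 1 to compound 2 (0.01 log units; within the scatter). All three are small, although three compounds are a thin basis and none of them carries the new group.

No step beyond the scatter is therefore expected in this assay. The expected change is a 1.3-fold lower number from compound 3 to compound 4 (0.11 log units; within the scatter), which would leave the series level. For compound 4 the estimate is 9000 nM, with an expected range from 4500 nM to 18000 nM.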

Compound 4, half-maximal inhibitory concentration: 13100 nM
Beside the measured number, compound 4's estimate is 1.5-fold (0.16 log units) below it; the range from low to high includes it.
By their numbers in this assay, from the lowest: compounds 2, 1, 3 and 4 (each within the scatter of the next).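

In this assay, replacing 3,5-dibromopyridin-2-yl with 3-bromopyridin-4-yl gives a 1.1-fold higher number from compound 3 to compound 4 (0.06 log units; within the scatter), and the comparison with the methoxy-bearing group gives a 1.7-fold higher number from compound 2 to compound 4 (0.22 log units; within the scatter), so the new group also leaves the series level. Compound 1 and compound 4 form the cleanest pair so far, differing only by bromo in place of hydrogen on an aromatic carbon, and that step is a 1.6-fold higher number from compound 1 to compound 4 (0.21 log units; within the scatter), so this single bromine makes no difference that can be told from scatter. All four groups on the amide-type nitrogen now fall within the scatter of each other, but nothing measured here gives a reason for this flat result.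

Going by these compounds, all four groups are substituted or plain pyridinyl rings, so it remains open whether a group of another kind at this position, such as a morpholine ring, a carboxylic acid or a longer alkyl chain, would shift the number beyond the scatter. The compounds also leave open whether this position stays as flat with changes elsewhere on the shared core, which is identical in all four.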